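The source may report more compounds than this note shows. Statements on the series, on what has been measured and on what is new or still open speak of the compounds shown alone.

Compound 3 `CC(C)=CCC/C(C)=C/COc1cc(=O)n(CCCO)c2c1CC(C/C=C(\C)CCC=C(C)C)C(C)(C)C2` stands lowest of the three numbers in a functional assay on PANC-1 cells (Homo sapiens) for inhibition, read by MTT assay, with a stated time of 24 h, tested at 10 uM; a lower number here means less inhibition, a higher number more inhibition at the concentration tested (going by the name of the read-out): in this assay compound 3 gives 3.1%. Compound 2 `CC(C)=CCC1Cc2c(OCCCNC(=O)c3ccco3)cc(=O)n(CCCO)c2CC1(C)C` gives 4.3%, a gap to compound 3 that lies within the scatter. Compound 1 `CC(C)=CCC/C(C)=C/COc1cc(=O)n(CCCO)c2c1CC(CC=C(C)C)C(C)(C)C2` gives 18.4% and is the only one clearly apart from the others. Both steps measured so far run downward: a number 14.1 percentage points lower from compound 1 to compound 2 (beyond the scatter) and a number 15.3 percentage points lower from compound 1 to compound 3 (beyond the scatter). Compound 4 `CC(C)=CCC/C(C)=C/CC1Cc2c(OC(=O)Nc3ccc(F)c(Cl)c3)cc(=O)n(CCCO)c2CC1(C)C` differs from compound 3 by (3-chloro-4-fluorophenyl)carbamoyl in place of 3,7-dimethylocta-2,6-dien-1-yl on an oxygen on an aromatic ring. Among the compounds with values here, no measured step makes this exact change. The nearest is the step from compound 1 to compound 2, where a chain carrying an amide took the place of the unsaturated chain on the ring oxygen and the number fell modestly; here the ring oxygen carries a carbamoyl group bearing an aromatic ring instead. Since compound 3 already sits at the bottom, little room remains below it, and a step within the scatter is expected: a number 4.9 percentage points higher from compound 3 to compound 4 (within the scatter). Compound 4 is therefore estimated at 8%, between 0% and 25%.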

Compound 4, a percentage reported as inhibition, at one concentration (the size of the read-out at that concentration, not a potency): 0%
The estimate for compound 4 lay 8 percentage points above the measured number; the range from low to high includes it.
By their numbers in this assay, from the lowest: compounds 4, 3 and 2 (each within the scatter of the next); then compound 1.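

In this assay, the (3-chloro-4-fluorophenyl)carbamoyl group on the ring oxygen gives a number 3.1 percentage points lower from compound 3 to compound 4 (within the scatter), so with the 3,7-dimethylocta-2,6-dien-1-yl group kept elsewhere on the core, this exchange produces no readable response. This differs from the earlier change at the same oxygen, a number 14.1 percentage points lower from compound 1 to compound 2 (beyond the scatter), but that step started from the higher number of compound 1, whereas compound 3 starts at 3.1% and leaves little room for any fall to be read. No evidence is available on why this exchange behaves as it does.

Open, going by these compounds, is whether the same carbamoyl group would lower the number when the 3-methylbut-2-en-1-yl group of compound 1 is retained. Also open, on these data alone, is whether a carboxylic acid or a morpholine on the chain at the ring oxygen would raise the number.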